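What replacing 4-methoxyphenyl might do in compound 4

The source may report more compounds than this note shows. Statements on the series, on what has been measured and on what is new or still open speak of the compounds shown alone.

compound 1 `COc1ccc(Nc2nc3ccccc3nc2S(=O)(=O)c2ccccc2)cc1` gives 640 nM
compound 2 `Cc1ccc(S(=O)(=O)c2nc3ccccc3nc2Nc2cccc(N)c2)cc1` gives 1080 nM
compound 3 `COc1ccc(Nc2nc3ccccc3nc2S(=O)(=O)c2ccc(OC)cc2)cc1` gives 1190 nM

All three numbers come from a functional assay on HL-60 cells (Homo sapiens) for cytotoxicity, read by MTT assay, with a stated time of 72 h (a lower number here means a stronger inhibitor, a higher number a weaker inhibitor), and they sit close together. Compound 3 lies within the usual scatter of both compound 1 and compound 2, so it cannot be ranked against either of them.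

The next compound is compound 4 `COc1ccc(S(=O)(=O)c2nc3ccccc3nc2Nc2cccc(N)c2)cc1`, which differs from compound 3 in one place (3-aminophenyl in place of 4-methoxyphenyl on a nitrogen on an aromatic ring). In words, 3-aminophenyl stands in place of 4-methoxyphenyl on a nitrogen on an aromatic ring.

Among the compounds with values here, only one measured step links two compounds that differ in a single place. This is a 1.9-fold higher number from compound 1 to compound 3 (0.27 log units; within the scatter), and it involves a different change, methoxy in place of hydrogen on an aromatic carbon. Compound 2 also carries 3-aminophenyl on that nitrogen, and compound 2 gives 1080 nM as its value, within the scatter of compound 3. Going by these compounds, no measurement isolates this swap, so its direction stays open, and no step beyond the scatter is expected in this assay.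

The expected change is a 1.1-fold lower number from compound 3 to compound 4 (0.03 log units; within the scatter), and this is only an estimate. For compound 4 the estimated value is 1100 nM, with an expected range from 500 nM to 2400 nM.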

Compound 4, half-maximal inhibitory concentration: 1490 nM
Estimate against measurement, compound 4: 1.4-fold (0.13 log units) below; low and high end bracket the measured number.
By their numbers in this assay, from the lowest: compounds 1, 2, 3 and 4 (each within the scatter of the next, the first and the last beyond it).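

In this assay, within the data shown here, the swap on this nitrogen can now be read directly for the first time: 3-aminophenyl in place of 4-methoxyphenyl gives a 1.3-fold higher number from compound 3 to compound 4 (0.10 log units; within the scatter). Among these compounds, earlier, the only hint came from compound 2, which carries the same 3-aminophenyl group but also differs from compound 3 elsewhere, whereas this step isolates the change, and it shows that these two groups cannot be told apart here. A second single change, methoxy in place of methyl on an aromatic carbon with 3-aminophenyl held on the nitrogen, gives a 1.4-fold higher number from compound 2 to compound 4 (0.14 log units; within the scatter), so that swap also leaves no readable mark, and nothing available explains either result.

Going by these compounds, both groups compared on this nitrogen are substituted phenyl rings, so it remains open whether something quite different there, such as a cyclohexyl ring or a longer alkyl chain, would move the number beyond the scatter. On these data alone, it is also open whether a carboxylic acid in place of the amine on the 3-aminophenyl group would do so.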